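This account rests on a few compounds, and the source may have more. Where it says the series, first, only, none or still open, it means among the compounds named here.

Measured so far in an ADME assay for pharmacokinetics, at pH 7.4; a lower number here means that the compound disappears faster, a higher number that the compound lasts longer:

compound 1 `COc1ccnc(C[S+]([O-])c2nc3cc(OC(F)F)ccc3[nH]2)c1` gives 51 h
compound 2 `COc1ccnc(C[S+]([O-])c2nc3cc(OC(F)F)ccc3[nH]2)c1C` gives 3 h
compound 3 `COc1ccnc(C[S+]([O-])c2nc3cc(OC(F)(F)C(F)F)ccc3[nH]2)c1` gives 63 h

The change from compound 1 to compound 2 is methyl in place of hydrogen on an aromatic carbon. In this assay it made a large step: a 17-fold lower number from compound 1 to compound 2 (1.23 log units; beyond the scatter).

The two cores differ as difluoromethyl in place of hydrogen on a saturated chain carbon bound to two fluorine atoms and an oxygen on an aromatic ring. Among the compounds with values here, that change made no step worth the name: a 1.2-fold higher number from compound 1 to compound 3 (0.09 log units; within the scatter), so compound 1 and compound 3 are read as alike in this assay.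

Compound 4 `COc1cc(C[S+]([O-])c2nc3cc(OC(F)(F)C(F)F)ccc3[nH]2)ncc1C` is not yet measured. It differs from compound 3 by methyl in place of hydrogen on an aromatic carbon. This is the same kind of change as that from compound 1 to compound 2, but not the same: in compound 2 the methyl sits ortho to a large group, whereas in compound 4 it sits para to a large group; both sit ortho to a methoxy group and two atoms from the ring nitrogen.

Within the data shown here, the expectation for compound 4 rests on the one measured pair, where a 17-fold lower number from compound 1 to compound 2 (1.23 log units; beyond the scatter) followed the same kind of change, applied to the starting point of compound 3 at 63 h. Among the measured compounds shown here, the shift in place has no measured counterpart here, so the expected step is held smaller than the measured one and the range is kept wide: for compound 4 the expected step is a 4.2-fold lower number from compound 3 to compound 4 (0.62 log units; beyond the scatter).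

Compound 4 is estimated at 15 h in this assay, with a range from 4 h to 50 h.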

Compound 4, half-life in the ADME assay: 18 h
For compound 4 the middle estimate is 1.2-fold (0.08 log units) below the measured one; the range from low to high includes it.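

In the ADME assay compound 3 gives 63 h and compound 4 gives 18 h. In the ADME assay, methyl in place of hydrogen on an aromatic carbon again goes with a lower number, a 3.5-fold lower number from compound 3 to compound 4 (0.54 log units; beyond the scatter), and the direction of the step carries from one core to the other while its size does not: the same change on two cores in the ADME assay, a 17-fold lower number (1.23 log units; beyond the scatter) from compound 1 to compound 2 and a 3.5-fold lower number (0.54 log units; beyond the scatter) from compound 3 to compound 4, 4.9-fold (0.69 log units) apart, beyond the scatter of two such steps

This does not show that the core alone sets the size of the step, since the two pairs also differ in where the methyl sits: ortho to a large group in compound 2, para to a large group in compound 4. In a physicochemical assay for acid dissociation, compound 3 gives 7.91 and compound 4 gives 8. In the physicochemical assay, the same change gives a number 0.09 log units higher from compound 3 to compound 4 (within the scatter), which reads compound 3 and compound 4 as alike there and offers no account of the gap between the two steps.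

The compounds shown leave open whether core or place accounts for that gap, a question that a methyl ortho to a large group on the core of compound 3 would help to settle. Also open, going by these compounds, is how the half-life responds when something other than methyl enters at these carbons, such as a chlorine, an amine or a longer chain.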